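The source may report more compounds than this note shows. Statements on the series, on what has been measured and on what is new or still open speak of the compounds shown alone.

For the measured compounds named here, in a functional assay on MDA-MB-231 cells (Homo sapiens) for antiproliferative activity, read by MTT assay, with a stated time of 72 h (on this read-out lower numbers stand for stronger inhibition and higher numbers for weaker inhibition), compound 2 `O=C(CCc1cccc2c1B(O)OC2)Nc1cccc(Br)c1` gives 720 nM, the lower of the two numbers so far, while compound 1 `O=C(CCc1cccc2c1B(O)OC2)Nc1ccc(Cl)cc1` gives 3600 nM. Compound 3 `O=C(CCc1cccc2c1B(O)OC2)Nc1cccc(I)c1` differs from compound 2 at one place: iodo in place of bromo on an aromatic carbon, meta to a large group. Going by the values given here, the only measured step, a 5.0-fold lower number from compound 1 to compound 2 (0.70 log units; beyond the scatter), is more than a swap of one halogen for another, so it bears on this change only loosely. No step beyond the scatter is therefore expected in this assay. The expected step is a 1.1-fold lower number from compound 2 to compound 3 (0.04 log units; within the scatter). Compound 3 is estimated at 650 nM, with an expected range of 250 nM to 1700 nM.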

Compound 3, half-maximal inhibitory concentration: 5300 nM
Compound 3: the middle estimate sits 8.2-fold (0.91 log units) below what was measured; the measured number lies above the stated range.
By their numbers in this assay, from the lowest: compound 2; then compounds 1 and 3 (each within the scatter of the next).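

In this assay, the two heavier halogens are not interchangeable on this aromatic carbon, meta to a large group: iodo in place of bromo gives a 7.4-fold higher number from compound 2 to compound 3 (0.87 log units; beyond the scatter). The 3-iodophenyl group also shows no separation from 4-chlorophenyl, with a 1.5-fold higher number from compound 1 to compound 3 (0.17 log units; within the scatter), so among these three compounds only compound 2, with its 3-bromophenyl group, stands apart. Nothing available accounts for the bromo-to-iodo step.

As far as these compounds go, whether the lower number extends to chloro or methoxy at this same place remains open. So does how an amine or a carboxylic acid there would compare with bromo.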